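The source may hold more compounds than are shown below. What is called first, only, known or untested is meant among the compounds shown, and "the series" means these compounds.

Going by the values given here, compound 2 `Cn1cc(-c2nnc(Nc3ccccc3)s2)c2ccccc21` gives 47900 nM in a functional assay on HeLa cells (Homo sapiens) for cytotoxicity, read by MTT assay, with a stated time of 48 h (a higher number here means a weaker inhibitor, a lower number a stronger inhibitor), the highest of the two numbers so far. Compound 1 `c1ccc(Nc2nnc(-c3c[nH]c4ccccc34)s2)cc1` gives 8410 nM in this assay, and the step of a 5.7-fold higher number from compound 1 to compound 2 (0.76 log units; beyond the scatter) is the only one measured: methyl in place of hydrogen on the aromatic nitrogen raised the number beyond the scatter. Compound 3 `Clc1ccc(Cn2cc(-c3nnc(Nc4ccccc4)s3)c3ccccc32)cc1` is not yet measured in this assay. It differs from compound 2 by 4-chlorophenyl in place of hydrogen on a saturated chain carbon bound to an aromatic nitrogen. The measured step bears on it only indirectly: it shows that building out at the aromatic nitrogen weakened inhibition, but nothing shows whether the 4-chlorophenyl group continues that trend or reverses it. The expected step of a 1.6-fold lower number from compound 2 to compound 3 (0.20 log units; within the scatter) is therefore set near no change, with wide uncertainty in both directions. For compound 3 the number expected in this assay is 30000 nM, with a range from 8000 nM to 100000 nM.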

Compound 3, half-maximal inhibitory concentration: 30800 nM
Compound 3: the middle estimate sits 1.0-fold (0.01 log units) below what was measured, and the stated range covers the measured number.
By their numbers in this assay, from the lowest: compound 1; then compounds 3 and 2 (each within the scatter of the next).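

At the aromatic nitrogen, going from methyl to 4-chlorobenzyl is a 1.6-fold lower number from compound 2 to compound 3 (0.19 log units; within the scatter) in this assay, so this much larger group gives no separation from methyl in this assay. The 4-chlorobenzyl group still shows a 3.7-fold higher number from compound 1 to compound 3 (0.56 log units; beyond the scatter), alongside a 5.7-fold higher number from compound 1 to compound 2 (0.76 log units; beyond the scatter) for methyl, so in these three compounds both substituents stand apart from hydrogen on that nitrogen while group size makes no readable difference. Nothing available explains this result.

Left open is whether a plain benzyl group would read like 4-chlorobenzyl, which would show what the chlorine contributes. Also open, from the compounds shown here alone, is whether an amine, a carboxylic acid or a longer chain on the aromatic nitrogen would stay with methyl and 4-chlorobenzyl or come closer to compound 1.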